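Methyl for chloro on a fused bicyclic core

A few compounds are considered here, and "the series" means these few. Any claim that something is new, unique, unknown or untested is made for them only; others in the source may bear on it.

Measured so far in a physicochemical assay for lipophilicity, at pH 3; a higher number here means a more lipophilic compound, a lower number a more polar compound:
compound 1, `CC(C)Nc1nc(NCc2ccco2)c2cccc(Cl)c2n1`: 2.38
compound 2, `CC(C)Nc1nc(NCc2ccco2)c2cc(Cl)ccc2n1`: 2.6
compound 3, `Cc1cccc2c(NCc3ccco3)nc(NC(C)C)nc12`: 1.57

Compound 2 has the highest of the three numbers; compound 1 lies within the scatter of it, while compound 3 lies beyond the scatter below it. Compound 1 and compound 2 share the same atoms joined differently, and the difference between the two cores is not broken down here. From compound 1 to compound 3 the change is methyl in place of chloro on an aromatic carbon, and in this assay it made the step of a number 0.81 log units lower from compound 1 to compound 3 (beyond the scatter).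

Compound 4, `Cc1ccc2nc(NC(C)C)nc(NCc3ccco3)c2c1`, is not yet measured. It differs from compound 2 by methyl in place of chloro on an aromatic carbon, the same kind of change as from compound 1 to compound 3, though the place is not the same: there the carbon was ortho to a fused ring and meta to a fused ring, here it is meta to a fused ring and para to a fused ring. Resting on the step of a number 0.81 log units lower from compound 1 to compound 3 (beyond the scatter), the expected step is a number 0.80 log units lower from compound 2 to compound 4 (beyond the scatter). Compound 4 is therefore estimated at 1.8, between 1.5 and 2.1.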

Compound 4, distribution coefficient: 1.55
For compound 4 the middle estimate is 0.25 log units above the measured one; the measured number falls inside the stated range.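

In this assay methyl in place of chloro on an aromatic carbon again gave a lower number, a number 1.05 log units lower from compound 2 to compound 4 (beyond the scatter), which matches the direction of a number 0.81 log units lower from compound 1 to compound 3 (beyond the scatter), and both steps lie beyond the scatter. For the compounds shown here, these are only two pairs, with the change at a different carbon in each, so they show the direction carrying over within these four compounds but set no general rule for the size of the step. Nothing shown explains why the number falls with this change.

Going by these compounds, how fluoro, bromo or methoxy would compare with chloro and methyl on these carbons remains open. So does whether the step would hold with an amine or a carboxylic acid elsewhere on the compound.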